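The source may hold more compounds than are shown below. What is called first, only, known or untested is meant among the compounds shown, and "the series" means these compounds.

Compound 1 `Fc1ccc(-c2nc3cc(C(F)(F)F)ccc3[nH]2)cc1`: 25000 nM
Compound 2 `O=C(CN1CCCC1)Nc1ccc(-c2nc3cc(C(F)(F)F)ccc3[nH]2)cc1`: 29000 nM
Compound 3 `O=C(CCl)Nc1ccc(-c2nc3cc(C(F)(F)F)ccc3[nH]2)cc1`: 22000 nM

These three compounds share one core and were all tested in an ADME assay on BHK cells (Mesocricetus auratus) for cytotoxicity, read by MTT assay, with a stated time of 96 h; a higher number here means that more compound is tolerated, a lower number that less compound is tolerated. On the numbers shown, compound 3 sits at the low end, yet both gaps to the others are within the scatter: a 1.1-fold lower number from compound 1 to compound 3 (0.06 log units; within the scatter) and a 1.3-fold lower number from compound 2 to compound 3 (0.12 log units; within the scatter). The third comparison, a 1.2-fold higher number from compound 1 to compound 2 (0.06 log units; within the scatter), is equally small, so swapping the whole arm on the shared core has so far moved nothing beyond the scatter.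

Compound 4 `CC(=O)Nc1ccc(-c2nc3cc(C(F)(F)F)ccc3[nH]2)cc1` has not yet been measured in this assay. It differs from compound 3 by hydrogen in place of chloro on a saturated chain carbon bound to a carbonyl carbon. The step that bears most directly on this change is a 1.3-fold lower number from compound 2 to compound 3 (0.12 log units; within the scatter), which touched the same carbon with a larger group exchange and stayed within the scatter. The expectation for compound 4 is therefore no step beyond the scatter, a 1.2-fold higher number from compound 3 to compound 4 (0.07 log units; within the scatter). The estimated value for compound 4 in this assay is 26000 nM, with a range from 13000 nM to 52000 nM.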

Compound 4, half-maximal cytotoxic concentration: 53000 nM
For compound 4 the middle estimate is 2.0-fold (0.31 log units) below the measured one; measured number outside the range, above it.
By their numbers in this assay, from the lowest: compounds 3, 1, 2 and 4 (each within the scatter of the next, the first and the last beyond it).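

Among the previous compounds no exchange cleared the scatter, but at the saturated chain carbon bound to a carbonyl carbon, hydrogen in place of chloro does so in this assay (a 2.4-fold higher number from compound 3 to compound 4 (0.38 log units; beyond the scatter)). Hydrogen in place of pyrrolidin-1-yl at that same carbon stays within the scatter (a 1.8-fold higher number from compound 2 to compound 4 (0.26 log units; within the scatter)), so the outcome at this carbon depends on which group leaves, while acetamido in place of fluoro on an aromatic carbon also clears it (a 2.1-fold higher number from compound 1 to compound 4 (0.33 log units; beyond the scatter)). No measurement shown explains why the chloro compound and the acetamido compound differ.

Going by these compounds, it remains open whether the step is specific to chloro or would also follow the loss of another atom, such as bromo or fluoro, from this carbon. A hydroxy group or a longer chain on this carbon could show how the number responds to groups other than hydrogen, chloro and pyrrolidin-1-yl.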